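Replacing 2-carboxyphenyl with benzyl on the aryl ether oxygen

The source may report more compounds than this note shows. Statements on the series, on what has been measured and on what is new or still open speak of the compounds shown alone.

Compound 1 `Cc1ccccc1-n1nc(C)c2c1NC(=O)[C@H](C)S[C@@H]2c1ccc(Oc2ccccc2C(=O)O)cc1` carries a 2-carboxyphenoxy group on its pendant aromatic ring. In an assay on isolated protein for agonist activity at Bile acid receptor (Homo sapiens), read by AlphaScreen, with a stated time of 30 min (a higher number here means that more compound is needed for the effect, a lower number that less compound is needed), compound 1 is reported as "not active" (no number reported), so no number stands for it, and it cannot be placed on a scale against the other compounds. Compound 2 `Cc1nn(-c2ccccc2F)c2c1C(c1ccc(Oc3ccccc3)cc1)SC(C)C(=O)N2` shares the core but has a plain phenoxy group in that position and a different substituent on the pyrazole nitrogen; in this assay compound 2 gives 3900 nM.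

Compound 3 `Cc1ccccc1-n1nc(C)c2c1NC(=O)[C@H](C)S[C@@H]2c1ccc(OCc2ccccc2)cc1` is the unmeasured analogue of compound 1. The change from compound 1 to compound 3 is benzyl in place of 2-carboxyphenyl on an oxygen on an aromatic ring. No measured step for this change exists among the compounds shown.

Since compound 1 was inactive in this assay while compound 2, which also lacks the 2-carboxyphenyl group, gave 3900 nM, the removal of that group in compound 3 is expected to move the compound from inactive into the measurable range, a step in the direction of less compound needed. For compound 3 in this assay the half-maximal effective concentration is estimated at 5000 nM, with a range from 1500 nM to 20000 nM.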

Compound 3, half-maximal effective concentration: "not active" (no number reported)
Compound 3 has no reported number here, and the estimate cannot be compared.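

In this assay, going by these compounds alone, compound 1 ("not active" (no number reported)) and compound 3 ("not active" (no number reported)) both lack a number, so no step between them can be read. No evidence bearing on this result is at hand. The compounds shown leave open whether benzyl and 2-carboxyphenyl on this oxygen differ in their effect at all.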